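The compounds below may be only part of what the source reports. "The series", "measured", "known", "first", "only" and "open" are said of these compounds alone.

Compound 1 `O=C1OC(Cc2nc(Cc3ccccc3)no2)c2ccccc21` was tested in a functional assay on RAW264.7 cells (Mus musculus) for inhibition, read by Griess assay, with stated times of 1 h and 24 h (a higher number here means a weaker inhibitor, a lower number a stronger inhibitor), and reached only the limit of the measurement, > 10000 nM. Compound 2 `CCOc1ccc(C(O)C2OC(=O)c3c(OC)cc(OC)cc32)cc1` likewise stops at the limit in this assay, giving > 10000 nM, which is not a number but the edge of what the assay can report. Both results sit at the limit of > 10000 nM in this assay, at which 2 of the 2 values shown sit. Compound 3 `CCOCCOc1ccc(C(O)C2OC(=O)c3c(OC)cc(OC)cc32)cc1` differs from compound 2 by ethoxy in place of hydrogen on a saturated chain carbon, two bonds along the chain from an oxygen on an aromatic ring. With nothing in hand to suggest that the change alters potency, the expected step is a step that the limit leaves unreadable from compound 2 to compound 3, none beyond the usual scatter. Compound 3 is therefore estimated at 15000 nM, within a range from 5000 nM to 50000 nM, most likely again reported only as a limit.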

Compound 3, half-maximal inhibitory concentration: > 10000 nM
Compound 3 gave a limit, no number (the forecaster's own chance of this, stated with the estimate: 80%); the middle value does not contradict the limit.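

No step can be read from compound 2 to compound 3, as both results are limits and not numbers. The compounds shown leave open whether the added ethoxy changes potency at all in this assay.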